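Shortening the amine chains on compound 2

A few compounds are considered here, and "the series" means these few. Any claim that something is new, unique, unknown or untested is made for them only; others in the source may bear on it.

Measured in a functional assay (aorta) with Rattus norvegicus as the target; a higher number here means a weaker inhibitor, a lower number a stronger inhibitor:
- compound 1 `COc1ccc(CN(C)CCCCOc2ccc(S(=O)(=O)c3c(C(C)C)cn4ccccc34)cc2)cc1OC`: 14.6 nM
- compound 2 `CCCCCN(CCCCC)CCCOc1ccc(S(=O)(=O)c2c(C(C)C)cn3ccccc23)cc1`: 89.6 nM
- compound 3 `CCCCc1cn2ccccc2c1S(=O)(=O)c1ccc(OCCCN(CCCC)CCCC)cc1`: 284 nM

Compound 2 lies in the middle of these three numbers, and its gaps to compound 1 and compound 3 are both beyond the scatter. Compound 4 `CCCN(CCC)CCCOc1ccc(S(=O)(=O)c2c(C(C)C)cn3ccccc23)cc1` has dipropylamino in place of dipentylamino on a saturated chain carbon, three bonds along the chain from an oxygen on an aromatic ring. Going by the values given here, no measured pair isolates this change. Compound 3, at 284 nM, differs from compound 2 in more than one place, so it offers only a loose hint toward a higher number. The expected change in this assay is a 1.6-fold higher number from compound 2 to compound 4 (0.19 log units; within the scatter), a modest move toward weaker inhibition. The estimated value for compound 4 is 140 nM, within an expected range of 45 nM to 430 nM.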

Compound 4, half-maximal inhibitory concentration: 102 nM
Compound 4: the middle estimate sits 1.4-fold (0.14 log units) above what was measured; measured number inside the range.
By their numbers in this assay, from the lowest: compound 1; then compounds 2 and 4 (each within the scatter of the next); then compound 3.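

In this assay the step is a 1.1-fold higher number from compound 2 to compound 4 (0.06 log units; within the scatter) and lies within the scatter. Going by these compounds alone, at this place on the chain, dipropylamino therefore reads the same as dipentylamino, a direct comparison that the earlier compounds could not give. Nothing measured here bears on what lies behind this result.

Still open, going by these compounds, is whether a much smaller group such as dimethylamino would read the same at this place. On these data alone, a ring amine such as piperidine also remains untested by these compounds.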